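Branching a Chain Substituent on a Weakly Antiproliferative Core

The compounds below may be only part of what the source reports. "The series", "measured", "known", "first", "only" and "open" are said of these compounds alone.

Measured so far:
compound 1, `CCCn1c(Cc2cc(OC)c(OC)c(OC)c2)nc2c(N)ncnc21`, 46800 nM
compound 2, `COc1cc(Cc2nc3c(N)ncnc3n2CCCC(C)C)cc(OC)c1OC`, 69200 nM

These two compounds share a core and differ only in the chain carried on the aromatic nitrogen. In a functional assay on MCF7 cells (Homo sapiens) for antiproliferative activity (on this read-out higher numbers stand for weaker inhibition and lower numbers for stronger inhibition), compound 1 gives 46800 nM, and compound 2 gives 69200 nM. Among the compounds with values here, the one step known, a 1.5-fold higher number from compound 1 to compound 2 (0.17 log units; within the scatter), shows that lengthening and branching the chain left the read-out essentially unchanged. Compound 2 holds the higher of the two numbers, yet its gap to compound 1 lies within the scatter, so no order between them can be claimed.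

Compound 3, `COc1cc(Cc2nc3c(N)ncnc3n2CC2(C)CC2)cc(OC)c1OC`, carries the change (1-methylcyclopropyl in place of isopentyl on a saturated chain carbon bound to an aromatic nitrogen). Within the data shown here, the only step bearing on this change, a 1.5-fold higher number from compound 1 to compound 2 (0.17 log units; within the scatter), was within the scatter, and it concerned the outer part of the same chain; nothing measured here speaks to a three-membered ring. A step of no clear size is therefore expected, a 1.3-fold lower number from compound 2 to compound 3 (0.10 log units; within the scatter). Compound 3 is estimated at 55000 nM, within 20000 nM to 150000 nM.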

Compound 3, half-maximal inhibitory concentration: 112000 nM
Estimate against measurement, compound 3: 2.0-fold (0.31 log units) below, and the stated range covers the measured number.
By their numbers in this assay, from the lowest: compounds 1, 2 and 3 (each within the scatter of the next, the first and the last beyond it).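

Replacing isopentyl with 1-methylcyclopropyl on a saturated chain carbon bound to an aromatic nitrogen gives a 1.6-fold higher number from compound 2 to compound 3 (0.21 log units; within the scatter) in this assay, so the ring-bearing group cannot be told apart from the open branched chain. Set against the ethyl reference, however, the same group gives a 2.4-fold higher number from compound 1 to compound 3 (0.38 log units; beyond the scatter) and this is the first step here to clear the scatter, showing a modest weakening and that this position does respond to what it carries. No measurement at hand offers a reason for this step.

The compounds shown leave open whether an amine or a carboxylic acid on this chain would shift the number further, in either direction. As far as these compounds go, all three also share one core, so how changes elsewhere on it would read remains unknown.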